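Changing the Basic Side Chain in a Chemokine Receptor Antagonist Series

The compounds below may be only part of what the source reports. "The series", "measured", "known", "first", "only" and "open" are said of these compounds alone.

Of the compounds shown here, three sharing a core have been measured in a functional assay on CCRF-CEM cells for antagonist activity at C-X-C chemokine receptor type 4 (Homo sapiens), read by calcium flux, with stated times of 25 min and 90 s; on this read-out lower numbers stand for stronger inhibition and higher numbers for weaker inhibition. Compound 2 `c1ccc2c(c1)CN[C@@H](CN(CCC1CCNCC1)[C@H]1CCCc3cccnc31)C2` gives 150 nM, the lowest number of the three. Compound 1 `c1ccc2c(c1)CN[C@H](CN(CCCN1CCNCC1)[C@H]1CCCc3cccnc31)C2` gives 1150 nM, and compound 3 `c1cnc2c(c1)CN[C@H](CN(CCCN1CCNCC1)[C@H]1CCCc3cccnc31)C2` gives 2640 nM. Within the data shown here, the one single-site step measured so far, a 2.3-fold higher number from compound 1 to compound 3 (0.36 log units; beyond the scatter), concerns the core rather than the side chain, so it bears only indirectly on the present question.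

Compound 4 `CN1CCN(CCCN(C[C@H]2Cc3ccccc3CN2)[C@H]2CCCc3cccnc32)CC1` differs from compound 2 by (4-methylpiperazin-1-yl)methyl in place of piperidin-4-yl on a saturated chain carbon, two bonds along the chain from an amine nitrogen. Among the measured compounds shown here, no measured step covers exactly this change. For the measured compounds named here, the closest guide is compound 1, whose side chain also ends in a piperazine ring and which gives a higher number in this assay than compound 2; compound 4 carries a methyl on that ring instead of a hydrogen, and there is no measured pair to show what that does. On this basis compound 4 is expected to give a higher number than compound 2, a step of about a 6.0-fold higher number from compound 2 to compound 4 (0.78 log units; beyond the scatter). Compound 4 is therefore estimated at 900 nM, with a likely range from 300 nM to 3000 nM.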

Compound 4, half-maximal inhibitory concentration: 125 nM
Compound 4: middle estimate off by 7.2-fold (0.86 log units), on the high side; measured number below the stated range.
By their numbers in this assay, from the lowest: compounds 4 and 2 (each within the scatter of the next); then compound 1; then compound 3.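

In this assay, the step of a 1.2-fold lower number from compound 2 to compound 4 (0.08 log units; within the scatter) shows that this end of the side chain can change considerably with no separable effect on the read-out: the ring gains a second nitrogen, the chain grows longer, and the count of hydrogen-bond donors falls from 1 to 0. Among these compounds, a piperazine ring in the side chain therefore does not by itself bring a number like the 1150 nM of compound 1, although compound 1 and compound 4 differ in more than one place, so this pair gives no clean step. The data offer no explanation for why these two side chains read alike.

As far as these compounds go, the step changes ring, chain and methyl together, so the contribution of each remains unknown. Also open, from the compounds shown here alone, is how an ethyl or acetyl group in place of the methyl, or a carboxylic acid at the end of the chain, would read.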